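Moving the trifluoromethyl group in compound 1

The compounds below may be only part of what the source reports. "The series", "measured", "known", "first", "only" and "open" are said of these compounds alone.

Compound 1 `O=C(CSc1ccc([N+](=O)[O-])cc1)N1N=C(c2cc3ccccc3oc2=O)C[C@@H]1c1ccccc1C(F)(F)F`: 7580 nM
Compound 2 `O=C(CSCc1ccco1)N1N=C(c2cc3ccccc3oc2=O)C[C@@H]1c1ccccc1C(F)(F)F`: 15700 nM
Compound 3 `CC1=NN(C(=O)CSc2nc3ccccc3s2)[C@@H](c2cc(Br)cc(Br)c2O)C1`: 7800 nM

In a functional assay on MGC-803 cells (Homo sapiens) for cytotoxicity, read by MTT assay, with a stated time of 48 h (on this read-out higher numbers stand for weaker inhibition and lower numbers for stronger inhibition), compound 1 and compound 3 cannot be told apart given the usual scatter, and together they form the low end of these three numbers. Compound 4 `O=C(CSc1ccc([N+](=O)[O-])cc1)N1N=C(c2cc3ccccc3oc2=O)C[C@@H]1c1ccc(C(F)(F)F)cc1` has the same atoms as compound 1, joined differently: 4-(trifluoromethyl)phenyl in place of 2-(trifluoromethyl)phenyl on a saturated ring carbon. Going by the values given here, the only measured step that changes one place, a 2.1-fold higher number from compound 1 to compound 2 (0.32 log units; beyond the scatter), is modest. It also lies elsewhere, on a sulfur, so it bears on this change only loosely, as a rough guide to how far one local change can move the number. No measured step shifts the trifluoromethyl group, so the data give no reason to expect either direction. The expected result is a 1.0-fold lower number from compound 1 to compound 4 (0.00 log units; within the scatter), which means no clear shift is anticipated in this assay. For compound 4 the estimate is 7500 nM, with an expected range from 3200 nM to 17000 nM.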

Compound 4, half-maximal inhibitory concentration: 10200 nM
Beside the measured number, compound 4's estimate is 1.4-fold (0.13 log units) below it; measured number inside the range.
By their numbers in this assay, from the lowest: compounds 1, 3, 4 and 2 (each within the scatter of the next, the first and the last beyond it).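

Within this assay, moving the trifluoromethyl group gives a 1.3-fold higher number from compound 1 to compound 4 (0.13 log units; within the scatter), so 2-(trifluoromethyl)phenyl and 4-(trifluoromethyl)phenyl cannot be told apart here. This is the only step shown at the saturated ring carbon, as the earlier step lay on a sulfur, and it shows that this shift of the group leaves no clear mark on the number when 4-nitrophenyl sits on the sulfur. No available measurement offers an explanation for this result.

As far as these compounds go, it remains open whether the two placements would also match with the (furan-2-yl)methyl group of compound 2 on the sulfur. From the compounds shown here alone, it is also open how far the number would move if a plain phenyl, a pyridine ring or a phenyl carrying an amine stood on the saturated ring carbon.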